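Methyl next to the ring nitrogen: compound 4 expected

The compounds below may be only part of what the source reports. "The series", "measured", "known", "first", "only" and "open" are said of these compounds alone.

Compound 1 `COc1cc(N(C)CCN(C)C)c(NC(=O)/C=C\C(C)C)cc1Nc1nccc(-c2cn(C)c3ccc(F)cc23)n1` gives 6140 nM in a functional assay on A549 cells (Homo sapiens) for antiproliferative activity, read by MTT assay, with a stated time of 72 h; a lower number here means a stronger inhibitor, a higher number a weaker inhibitor.
Compound 2 `CCC/C=C\C(=O)Nc1cc(Nc2nccc(-c3cn(C)c4ccc(F)cc34)n2)c(OC)cc1N(C)CCN(C)C` gives 1030 nM in this assay.
Compound 3 `CCC/C=C\C(=O)Nc1cc(Nc2ncc(C#N)c(-c3cn(C)c4ccc(F)cc34)n2)c(OC)cc1N(C)CCN(C)C` gives 741 nM in this assay.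

Compound 2 stands second highest of the three numbers; the nearest is compound 3, the furthest compound 1. The step of a 6.0-fold lower number from compound 1 to compound 2 (0.78 log units; beyond the scatter) is modest but clear, while a 1.4-fold lower number from compound 2 to compound 3 (0.14 log units; within the scatter) stays within the scatter. Compound 4 `CCC/C=C\C(=O)Nc1cc(Nc2nc(C)cc(-c3cn(C)c4ccc(F)cc34)n2)c(OC)cc1N(C)CCN(C)C` differs from compound 2 by methyl in place of hydrogen on an aromatic carbon. Among the compounds with values here, only the step from compound 2 to compound 3 bears on a change at the shared core, and it was small; no step shows the effect of a methyl at this place. Compound 4 is therefore expected to show a 1.2-fold higher number from compound 2 to compound 4 (0.07 log units; within the scatter), no step beyond the scatter. The estimate for compound 4 is 1200 nM, with a range from 400 nM to 3600 nM.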

Compound 4, half-maximal inhibitory concentration: 13300 nM
Compound 4: the middle estimate sits 11-fold (1.04 log units) below what was measured; the whole stated range lies below it.
By their numbers in this assay, from the lowest: compounds 3 and 2 (each within the scatter of the next); then compound 1; then compound 4.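

In this assay, methyl in place of hydrogen on an aromatic carbon, next to the ring nitrogen, gives a 13-fold higher number from compound 2 to compound 4 (1.11 log units; beyond the scatter) and is the largest single step among the compounds shown. The earlier change at the shared core, cyano in place of hydrogen, gave a 1.4-fold lower number from compound 2 to compound 3 (0.14 log units; within the scatter) and so did not show that one added heavy atom at an aromatic carbon of this core could cost this much. Nothing measured here accounts for the loss.

The compounds shown leave open whether chlorine, an amine or a longer chain at this carbon would give a similar loss. They also leave open whether methyl here would have the same effect alongside the cyano of compound 3.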